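Turning One Stereocentre: Compound 2 to Compound 4

The source may report more compounds than this note shows. Statements on the series, on what has been measured and on what is new or still open speak of the compounds shown alone.

compound 1 `COc1cc(C)[nH]c(=O)c1CN1CCc2c(Cl)cc(-c3c(C)noc3C)c(Cl)c2C1=O`: 27 nM
compound 2 `COc1cc(C)[nH]c(=O)c1CN1CCc2c(Cl)cc([C@H](O)C3COC3)c(Cl)c2C1=O`: 108 nM
compound 3 `CCOC(c1cc(Cl)c2c(c1Cl)C(=O)N(Cc1c(C)cc(C)[nH]c1=O)CC2)C1CS(=O)(=O)C1`: 5560 nM; 34 nM (2 entries)

In a functional assay on KARPAS-422 cells (Homo sapiens) for antiproliferative activity, read by resazurin assay, with a stated time of 72 h (a higher number here means a weaker inhibitor, a lower number a stronger inhibitor), compound 2 gives 108 nM, the higher of the two single numbers. Among the measured compounds shown here, the one measured step runs a 4.0-fold higher number from compound 1 to compound 2 (0.60 log units; beyond the scatter), but it exchanges a whole group and so says little about configuration. The next structure is compound 4 `COc1cc(C)[nH]c(=O)c1CN1CCc2c(Cl)cc([C@@H](O)C3COC3)c(Cl)c2C1=O`, and the change is slight: the two compounds have the same atoms and bonds and differ only in configuration as drawn: 1 of 1 stereo elements differ; a stereocentre at a saturated chain carbon is drawn R in compound 2 and S in compound 4. For the measured compounds named here, no measured pair isolates such a change. The nearest hint comes from compound 3, which is drawn without configuration at its chain carbon and whose entries lie far apart: the several entries of compound 3 in this assay, 5560 nM; 34 nM (2 entries). A sizeable step is therefore expected rather than none, though this is tentative. A move towards a higher number seems more likely, given the long upward reach in the several entries of compound 3 in this assay, 5560 nM; 34 nM (2 entries). The expected change is a 7.4-fold higher number from compound 2 to compound 4 (0.87 log units; beyond the scatter). For compound 4 the estimate is 800 nM, with an expected range from 100 nM to 5000 nM.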

Compound 4, half-maximal inhibitory concentration: 10600 nM
Compound 4: the middle estimate sits 13-fold (1.12 log units) below what was measured; the measured number lies above the stated range.
By their numbers in this assay, from the lowest: compound 1; then compound 2; then compound 4.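

The step of a 98-fold higher number from compound 2 to compound 4 (1.99 log units; beyond the scatter) shows that in this assay this saturated chain carbon is far from indifferent to configuration, with the R form as drawn in compound 2 clearly favoured over the S form. That whole step can be assigned to the stereocentre alone: the fact that compounds 2 and 4 differ only in the configuration as drawn. The cost of placing the four-membered non-aromatic ring on the aromatic carbon in place of the five-membered aromatic ring therefore depends on configuration, running a 4.0-fold higher number from compound 1 to compound 2 (0.60 log units; beyond the scatter) for the R form but a 390-fold higher number from compound 1 to compound 4 (2.59 log units; beyond the scatter) for the S form.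

The compounds shown do not settle whether a configurational difference of this kind underlies the wide spread for compound 3: the several entries of compound 3 in this assay, 5560 nM; 34 nM (2 entries). They also leave open whether the same preference would hold with an amine on the chain carbon.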